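The source may hold more compounds than are shown below. What is called first, only, known or untested is meant among the compounds shown, and "the series" means these compounds.

Measured so far in a functional assay on HL-60 cells (Homo sapiens) for cytotoxicity, read by WST assay, with a stated time of 48 h; on this read-out lower numbers stand for an effect already at smaller amounts and higher numbers for an effect only at larger amounts of compound:
compound 1 `O=C1OC[C@H](Cc2ccccc2)[C@H]1Cc1ccccc1OC(F)(F)F` gives 39000 nM
compound 2 `O=C1OC[C@H](Cc2ccccc2)[C@H]1Cc1ccccc1C(F)(F)F` gives 37000 nM
compound 3 `O=C1OC[C@H](Cc2ccccc2)[C@H]1Cc1ccccc1F` gives 72000 nM

Compound 3 stands within the scatter of both others, with steps of a 1.8-fold higher number from compound 1 to compound 3 (0.27 log units; within the scatter) and a 1.9-fold higher number from compound 2 to compound 3 (0.29 log units; within the scatter) on record. Compound 4 `O=C1OC[C@H](Cc2ccccc2)[C@H]1Cc1ccccc1Cl` has not yet been measured. It differs from compound 3 by chloro in place of fluoro on an aromatic carbon in one exchange: chloro in place of fluoro on an aromatic carbon, ortho to a large group. The steps bearing on this are those two exchanges at the same place, together with a 1.1-fold lower number from compound 1 to compound 2 (0.02 log units; within the scatter) as a third. All three lie within the scatter, so no step beyond the scatter is expected in this assay here. The expected step is a 1.4-fold lower number from compound 3 to compound 4 (0.16 log units; within the scatter) and stays within that scatter. For compound 4 the estimate is 50000 nM with an expected range of 25000 nM to 95000 nM in this read-out.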

Compound 4, half-maximal effective concentration: 37000 nM
The estimate for compound 4 lay 1.4-fold (0.13 log units) above the measured number; the measured number falls inside the stated range.
By their numbers in this assay, from the lowest: compounds 2, 4, 1 and 3 (each within the scatter of the next).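

In this assay, chloro joins the three earlier substituents at this position without any step leaving the scatter: it gives a 1.9-fold lower number from compound 3 to compound 4 (0.29 log units; within the scatter) against fluoro, no change at the digits printed from compound 2 to compound 4 (within the scatter) against trifluoromethyl and a 1.1-fold lower number from compound 1 to compound 4 (0.02 log units; within the scatter) against trifluoromethoxy. All four substituents therefore cannot be told apart at this position in this read-out, and the exchange of fluoro for chloro adds no step beyond the scatter. No supporting evidence bears on this result. Going by these compounds, whether an amine, a hydroxyl or a carboxylic acid at this position would give a step beyond the scatter stays open. So does whether any of these four substituents would behave alike elsewhere on the ring.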